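Taking the methyl off compound 3

The source may report more compounds than this note shows. Statements on the series, on what has been measured and on what is new or still open speak of the compounds shown alone.

Within the data shown here, in a functional assay on MCF7 cells (Homo sapiens) for inhibition, read by MTT assay, with a stated time of 72 h (on this read-out lower numbers stand for stronger inhibition and higher numbers for weaker inhibition), three related compounds have numbers so far. Compound 1 `Cc1ccc(-c2nnc(SCCCN3CCN(c4nc5ccccc5o4)CC3)o2)cc1` gives 60400 nM, compound 2 `Oc1ccc(-c2nnc(SCCCN3CCN(c4nc5ccccc5o4)CC3)o2)cc1` gives 260000 nM, and compound 3 `Cc1ccc(-c2nnc(SCCCN3CCN(c4nc5ccccc5s4)CC3)o2)cc1` gives 107000 nM. Compound 3 therefore lies within the usual scatter of compound 1, while compound 2 has the highest number of the three, beyond the scatter of both, and so the weakest inhibition.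

Compound 4 `c1ccc(-c2nnc(SCCCN3CCN(c4nc5ccccc5s4)CC3)o2)cc1` has not been measured. It carries hydrogen in place of methyl on an aromatic carbon of compound 3, so 4-methylphenyl becomes phenyl: hydrogen in place of methyl on an aromatic carbon. Among the measured compounds shown here, no measured pair makes exactly this change. The closest evidence also removes the methyl, but puts hydroxy there instead of hydrogen, and it gave a 4.3-fold higher number from compound 1 to compound 2 (0.63 log units; beyond the scatter). For the measured compounds named here, the other measured step, 1,3-benzothiazol-2-yl in place of 1,3-benzoxazol-2-yl, gave a 1.8-fold higher number from compound 1 to compound 3 (0.25 log units; within the scatter), and it shows only that compound 3 is a fair starting point next to compound 1. Since hydroxy is not hydrogen, that modest step sets no direction here, and no step beyond the scatter is expected in this assay. The estimated change is a 1.0-fold higher number from compound 3 to compound 4 (0.01 log units; within the scatter). For compound 4 the expected value is 110000 nM, with an estimated range from 50000 nM to 240000 nM.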

Compound 4, half-maximal inhibitory concentration: 76900 nM
For compound 4 the middle estimate is 1.4-fold (0.16 log units) above the measured one, within the range that was stated.
By their numbers in this assay, from the lowest: compounds 1, 4 and 3 (each within the scatter of the next); then compound 2.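

Among these compounds, the step of a 1.4-fold lower number from compound 3 to compound 4 (0.14 log units; within the scatter), measured in this assay, is the first direct reading of what removing this methyl does on its own, with nothing put in its place but hydrogen. On an aromatic carbon para to a large group, 4-methylphenyl and phenyl cannot be told apart on this read-out, so the methyl makes no difference here that stands out from repeat-measurement noise. That puts the earlier hydroxy step, a 4.3-fold higher number from compound 1 to compound 2 (0.63 log units; beyond the scatter), in a new light: in the pair with the benzothiazole-bearing compounds, losing the methyl alone gives no such step, though that hydroxy step was seen with 1,3-benzoxazol-2-yl on the amine nitrogen, and nothing here explains the difference.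

Still open, as far as these compounds go, is whether the phenyl form behaves the same with 1,3-benzoxazol-2-yl in place of 1,3-benzothiazol-2-yl, and whether hydroxy on the benzothiazole side repeats the step seen with hydroxy before. Also open, from the compounds shown here alone, is how other groups on this carbon, such as methoxy, chlorine, an amine or a carboxylic acid, would compare with hydrogen and methyl.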